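From propargyl to 4-methylbenzyl on the sulfur

This account rests on a few compounds, and the source may have more. Where it says the series, first, only, none or still open, it means among the compounds named here.

In a functional assay on PC-9 cells (Homo sapiens) for inhibition, read by MTT assay, with a stated time of 72 h (a lower number here means a stronger inhibitor, a higher number a weaker inhibitor), compound 1 `Cc1cc(Nc2cc(-c3ccccc3)[nH]n2)n2nc(SCc3ccccc3Br)nc2n1` gives 5630 nM, and compound 2 `Cc1cc(Nc2cc(-c3ccccc3)[nH]n2)n2nc(SCc3ccc(Cl)cc3)nc2n1` gives 6710 nM. Compound 3 `C#CCSc1nc2nc(C)cc(Nc3cc(-c4ccccc4)[nH]n3)n2n1` reads > 50000 nM, which is a limit of the assay and not a number.

Compound 4 `Cc1ccc(CSc2nc3nc(C)cc(Nc4cc(-c5ccccc5)[nH]n4)n3n2)cc1` carries 4-methylphenyl in place of ethynyl on a saturated chain carbon bound to a sulfur. The closest evidence runs the opposite way, with ethynyl entering: an at least 8.8-fold higher number from compound 1 to compound 3 (0.94 log units; beyond the scatter) and an at least 7.4-fold higher number from compound 2 to compound 3 (0.87 log units; beyond the scatter), both beyond the scatter. Between the two phenyl groups, a 1.2-fold higher number from compound 1 to compound 2 (0.08 log units; within the scatter), within the scatter.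

A step to a lower number is therefore expected, beyond the scatter. The estimated step is an at least 8.3-fold lower number from compound 3 to compound 4 (0.92 log units; beyond the scatter). Compound 4 is expected at 6000 nM, within an estimated range of 2500 nM to 15000 nM.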

Compound 4, half-maximal inhibitory concentration: 7310 nM
Estimate against measurement, compound 4: 1.2-fold (0.09 log units) below; measured number inside the range.
By their numbers in this assay, from the lowest: compounds 1, 2 and 4 (each within the scatter of the next). At a limit, above all of these: compound 3.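

With 4-methylphenyl in place of ethynyl on a saturated chain carbon bound to a sulfur, the change reads as an at least 6.8-fold lower number from compound 3 to compound 4 (0.83 log units; beyond the scatter), and that size is only a bound: the limit of > 50000 nM in this assay, at which 1 of the 4 values shown sits. Methyl in place of chloro on an aromatic carbon gives a 1.1-fold higher number from compound 2 to compound 4 (0.04 log units; within the scatter), and 4-methylphenyl in place of 2-bromophenyl gives a 1.3-fold higher number from compound 1 to compound 4 (0.11 log units; within the scatter). In this assay, the three substituted phenyl groups thus read alike at this position, whichever substituent they carry.

As far as these compounds go, whether a longer saturated chain without a ring would read with them stays open, as does a phenyl group carrying an amine or a carboxylic acid.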